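This account rests on a few compounds, and the source may have more. Where it says the series, first, only, none or still open, it means among the compounds named here.

Of the compounds shown here, three built on one shared core have been tested in a functional assay on MGC-803 cells (Homo sapiens) for inhibition, read by sulforhodamine B assay; on this read-out higher numbers stand for weaker inhibition and lower numbers for stronger inhibition. Compound 1 `O=C1C(NC2CC2)=CC(=O)c2c1nc1n2[C@H]2OC[C@@H](O)[C@H]2OC1` carries a cyclopropyl group on an amine nitrogen. In this assay compound 1 reaches only a limit of the assay, > 4000 nM, which is the limit of > 4000 nM in this assay, at which 1 of the 3 values shown sits. Compound 3 `O=C1C(Nc2ccc(Br)cc2)=CC(=O)c2c1nc1n2[C@H]2OC[C@@H](O)[C@H]2OC1` carries a 4-bromophenyl group in place of that cyclopropyl, and in this assay compound 3 gives 2020 nM; that step is an at least 1.9-fold lower number from compound 1 to compound 3 (0.29 log units; that floor lies within the scatter). Compound 2 `COc1cccc(NC2=CC(=O)c3nc4n(c3C2=O)[C@H]2OC[C@@H](O)[C@H]2OC4)c1` bears a 3-methoxyphenyl group on the same nitrogen, and in this assay compound 2 gives 1780 nM. Of the two plain numbers shown, that of compound 2 is the smaller, yet its gap to compound 3 lies within the scatter, so the two cannot be told apart.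

Compound 4 `COc1ccccc1NC1=CC(=O)c2nc3n(c2C1=O)[C@H]1OC[C@@H](O)[C@H]1OC3` is not yet measured. It differs from compound 2 by 2-methoxyphenyl in place of 3-methoxyphenyl on an amine nitrogen. Among the compounds with values here, no measured step exchanges a 3-methoxyphenyl for a 2-methoxyphenyl; the only measured step swaps a cyclopropyl for a 4-bromophenyl and therefore gives little guidance here. The expected step is thus one of no size beyond the scatter, a 1.1-fold higher number from compound 2 to compound 4 (0.05 log units; within the scatter). In this assay compound 4 is estimated at 2000 nM, within a range of 800 nM to 5000 nM.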

Compound 4, half-maximal inhibitory concentration: 1630 nM
For compound 4 the middle estimate is 1.2-fold (0.09 log units) above the measured one, and the stated range covers the measured number.
By their numbers in this assay, from the lowest: compounds 4, 2 and 3 (each within the scatter of the next). At a limit, above all of these: compound 1.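

Exchanging 3-methoxyphenyl for 2-methoxyphenyl on this amine nitrogen uses the same atoms, joined differently, and in this assay it gives a 1.1-fold lower number from compound 2 to compound 4 (0.04 log units; within the scatter). Within the data shown here, this is the first measured step between two groups of identical composition, and it shows that this assay cannot tell these two methoxyphenyl groups apart at this position. Among these compounds, compound 1, with its cyclopropyl group, remains the only compound at a limit: the limit of > 4000 nM in this assay, at which 1 of the 4 values shown sits.

The compounds shown leave open how 4-methoxyphenyl or a plain phenyl would read on the same nitrogen. They also leave open whether a carboxylic acid or a dimethylamino group on that aromatic ring, or a longer alkyl chain in its place, would give a step beyond the scatter.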